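The compounds below may be only part of what the source reports. "The series", "measured", "known", "first", "only" and "open" are said of these compounds alone.

The measured compounds:
compound 1, `CCOc1ccc(N/N=C2\CCC(C)n3c2ncc(C(=O)O)c3=O)cc1`, in a functional assay on the whole organism for inhibition, with Rattus norvegicus as the target (a lower number here means that less compound is needed, a higher number that more compound is needed for the effect), gives > 100 umol/kg, which is a limit of the assay and not an exact number.
compound 2, `Cc1ccc(N/N=C2\CCC(C)n3c2ncc(C(=O)O)c3=O)cc1`, in this assay gives > 1000 umol/kg, which is likewise a limit.

Compound 2 therefore stands only at a limit, with no exact number attached to it. The step that the two limits leave unreadable from compound 1 to compound 2 cannot be read, because the limit of > 100 umol/kg in this assay, at which 1 of the 2 values shown sits, and the limit of > 1000 umol/kg in this assay, at which 1 of the 2 values shown sits, are both limits rather than numbers. Compound 3, `CC1CC/C(=N\Nc2ccc(C(F)(F)F)cc2)c2ncc(C(=O)O)c(=O)n21`, differs from compound 2 by trifluoromethyl in place of methyl on an aromatic carbon. No readable measured step bears on this change, so no direction can be expected for the step in this assay beyond the scatter, and the most likely outcome is that compound 3 again returns only a limit. Compound 3 is estimated to give 1000 umol/kg in this assay, within the range 300 umol/kg to 3000 umol/kg. The step of a number no higher from compound 2 to compound 3 (the limit leaves the size open) is thus expected to be small.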

Compound 3, dose for 50% inhibition: > 1000 umol/kg
Compound 3: a limit, no number (the forecaster's own chance of this, stated with the estimate: 80%); the middle value sits exactly at the limit.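

Compound 3 also returns only a limit of the assay rather than a number, so the steps to it from compound 1 and from compound 2 cannot be read: the limit of > 1000 umol/kg in this assay, at which 2 of the 3 values shown sit.

The compounds shown leave open what dose any of the three needs in this assay, and whether the group on the aromatic carbon changes that dose.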